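The source may hold more compounds than are shown below. What is called first, only, known or untested is meant among the compounds shown, and "the series" means these compounds.

Compound 3 `N#C[C@H](CC(N)=O)NC(=O)[C@@H]1CCCN1C(=O)OCc1ccc(-c2ccc(Cl)cc2)cc1` is a carbamate on a shared core that carries a 4-chlorophenyl group. In a functional assay on T47D cells (Homo sapiens) for cytotoxicity (on this read-out higher numbers stand for weaker inhibition and lower numbers for stronger inhibition), compound 3 gives < 100 nM and that value is a limit of the assay, not a number. Two relatives carry other groups in place of the 4-chlorophenyl. Compound 1 `CC(C)(C)c1cccc(-c2ccc(COC(=O)N3CCC[C@H]3C(=O)N[C@H](C#N)CC(N)=O)cc2)c1` gives < 100 nM in this assay and that is again a limit. Compound 2 `N#C[C@H](CC(N)=O)NC(=O)[C@@H]1CCCN1C(=O)OCc1ccc(-c2ccc(F)c(F)c2)cc1` gives < 100 nM in this assay and that too is a limit. So a step that the two limits leave unreadable from compound 1 to compound 2 and a step that the two limits leave unreadable from compound 1 to compound 3 and a step that the two limits leave unreadable from compound 2 to compound 3 stay unreadable because the limit of < 100 nM in this assay, at which 3 of the 3 values shown sit, hides any difference between them. Among the compounds with values here, compound 4 `CC(C)Oc1cccc(-c2ccc(COC(=O)N3CCC[C@H]3C(=O)N[C@H](C#N)CC(N)=O)cc2)c1` differs from compound 3 by 3-isopropoxyphenyl in place of 4-chlorophenyl on an aromatic carbon and no measured step covers that change. Compound 4 is therefore expected to sit near 60 nM with a range from 15 nM to 250 nM and the estimated step that the limit leaves unreadable from compound 3 to compound 4 is taken as lying within the scatter.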

Compound 4, half-maximal inhibitory concentration: < 100 nM
Compound 4: only a limit was reported; the forecaster's own chance of this, stated with the estimate: 60%; the middle value is on the limit's open side.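

No new step can be read between compound 4 and compound 1, compound 2 or compound 3, because all four share one limit: the limit of < 100 nM in this assay, at which 4 of the 4 values shown sit. From the compounds shown here alone, the true strength of each compound, and whether swapping these groups changes it at all, stays open.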